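Series notes: chain replacement on the saturated ring of compound 1

The source may hold more compounds than are shown below. What is called first, only, known or untested is meant among the compounds shown, and "the series" means these compounds.

Measured so far:
compound 1 `C=CC[C@@H]1C[C@@H](c2ccc(Cl)c(Cl)c2)[C@H](NC(=O)c2cc(-c3c(Cl)cnn3C)c(Cl)o2)CN1` — 160 nM
compound 2 `Cn1ncc(Cl)c1-c1cc(C(=O)N[C@@H]2CN[C@H](CC(O)CO)C[C@H]2c2ccc(F)c(F)c2)oc1Cl` — 100 nM

Both compounds were run in a functional assay on LNCaP cells (Homo sapiens) for antiproliferative activity; a higher number here means a weaker inhibitor, a lower number a stronger inhibitor. Compound 1 gives 160 nM and compound 2 gives 100 nM. Of the two numbers, that of compound 1 is the higher, but the gap to compound 2 falls within the usual scatter, so the two cannot be told apart on these data. Within the data shown here, no pair of measured compounds differs in one place, so no measured step is available.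

The next compound, compound 3 `CN(C)CC[C@@H]1C[C@@H](c2ccc(Cl)c(Cl)c2)[C@H](NC(=O)c2cc(-c3c(Cl)cnn3C)c(Cl)o2)CN1`, is not yet measured. It differs from compound 1 as follows: (dimethylamino)methyl in place of vinyl on a saturated chain carbon bound to a saturated ring carbon. The shared core and the dichlorophenyl group are kept; only the chain on the saturated ring changes.

Without a measured step to anchor it, the expectation rests on compound 1 alone. The expected step from compound 1 to compound 3 in this assay is small, a 1.2-fold lower number from compound 1 to compound 3 (0.09 log units; within the scatter), not beyond the scatter in either direction. Compound 3 is therefore estimated at 130 nM, with a range from 50 nM to 400 nM.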

Compound 3, half-maximal inhibitory concentration: 1930 nM
Compound 3: middle estimate off by 15-fold (1.17 log units), on the low side; measured number outside the range, above it.
By their numbers in this assay, from the lowest: compounds 2 and 1 (each within the scatter of the next); then compound 3.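

In this assay, the chain on the saturated ring is not interchangeable: going from allyl to 2-(dimethylamino)ethyl with the shared core and the dichlorophenyl group kept gives a 12-fold higher number from compound 1 to compound 3 (1.08 log units; beyond the scatter), a large step beyond the scatter. Among these compounds, this is the first measured single-place step, and it shows that this position can move the read-out substantially. The change is nevertheless a composite one, since the double bond leaves while a larger group enters with a nitrogen and a hydrogen-bond acceptor, and no measurement on hand assigns the step to any one of these differences.

The compounds shown leave open whether the higher number follows the nitrogen, the dimethyl substitution on it or the chain itself, a question that a plain butyl chain and a primary amine on the same ethyl chain would help to separate. Also open, from the compounds shown here alone, is how a carboxylic acid at the chain end would read in this assay, and whether the step from allyl to 2-(dimethylamino)ethyl holds with another aryl group on the shared core.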